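The source may hold more compounds than are shown below. What is called first, only, known or untested is meant among the compounds shown, and "the series" means these compounds.

In a functional assay on SW-620 cells (Homo sapiens) (on this read-out lower numbers stand for stronger inhibition and higher numbers for weaker inhibition), compound 1 (`COc1cc(NC(C)CCCNC(=O)NCCO)c2ncccc2c1`) gives > 100000 nM, which is a limit of the assay. Within the data shown here, compound 2 (`COc1cc(NC(C)CCCNC(=O)NO)c2ncccc2c1`) gives 35000 nM, the only actual number so far. Compound 3 (`COC(=O)NCCCC(C)Nc1cc(OC)cc2cccnc12`) has methoxy in place of hydroxyamino on a carbonyl carbon. Among the measured compounds shown here, the one measured step bearing on this change is an at least 2.8-fold lower number from compound 1 to compound 2 (0.45 log units; beyond the scatter), which introduced hydroxy on an amide-type nitrogen and lowered the number. Losing hydroxyamino is therefore expected to shift this assay modestly toward weaker inhibition, an estimated 2.3-fold higher number from compound 2 to compound 3 (0.36 log units; beyond the scatter). For compound 3 the estimated value is 80000 nM, with an expected range of 30000 nM to 200000 nM.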

Compound 3, half-maximal inhibitory concentration: > 100000 nM
Compound 3 ended at the assay's limit; the forecaster's own chance of this, stated with the estimate: 50%; middle value at least 1.2-fold (0.09 log units) away from the limit.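

In this assay, methoxy in place of hydroxyamino on a carbonyl carbon gives an at least 2.8-fold higher number from compound 2 to compound 3 (0.45 log units; beyond the scatter), a step beyond the scatter. Hydroxyamino has now been replaced here by two different groups, and of the three compounds only compound 2, which keeps it, gives an actual number. Compound 3 sits at a limit, so its step shows only a minimum size and the step between the two limit compounds cannot be read: the limit of > 100000 nM in this assay, at which 2 of the 3 values shown sit.

As far as these compounds go, whether a carboxylic acid or a simple amine on this carbonyl carbon would give a measurable number remains open. So does the effect of a longer chain with hydroxyamino kept.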